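The source may report more compounds than this note shows. Statements on the series, on what has been measured and on what is new or still open speak of the compounds shown alone.

Working notes on the sulfonamide series in a functional assay on MDA-MB-231 cells (Homo sapiens) for antiproliferative activity, read by MTT assay, with a stated time of 72 h; on this read-out lower numbers stand for stronger inhibition and higher numbers for weaker inhibition.

Compound 1 `O=C(Nc1ccc(-c2noc(-c3cccc(NS(=O)(=O)c4ccc(C(F)(F)F)cc4)c3)n2)c(Cl)c1)c1cccnc1` carries a trifluoromethyl on the outer aromatic ring. In this assay compound 1 gives only a limit, > 10000 nM, which is the limit of > 10000 nM in this assay, at which 1 of the 3 values shown sits. Compound 2 `CNC(=O)Nc1ccc(S(=O)(=O)Nc2cccc(-c3nc(-c4ccc(NC(=O)c5cccnc5)cc4Cl)no3)c2)cc1` replaces that trifluoromethyl with a (methylcarbamoyl)amino group and in this assay compound 2 gives 1300 nM; the step is an at least 7.6-fold lower number from compound 1 to compound 2 (0.88 log units; beyond the scatter). Compound 3 `CCNC(=O)Nc1ccc(S(=O)(=O)Nc2cccc(-c3nc(-c4ccc(NC(=O)c5cccnc5)cc4Cl)no3)c2)cc1` carries the (ethylcarbamoyl)amino group instead and in this assay compound 3 gives 3100 nM, a step of an at least 3.2-fold lower number from compound 1 to compound 3 (0.50 log units; beyond the scatter). Between the two urea compounds the step is a 2.4-fold higher number from compound 2 to compound 3 (0.38 log units; beyond the scatter), so compound 3 stands as the higher of the two numbers measured so far, with compound 2 the only other number.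

Compound 4 `CCN(CC)C(=O)Nc1ccc(S(=O)(=O)Nc2cccc(-c3nc(-c4ccc(NC(=O)c5cccnc5)cc4Cl)no3)c2)cc1` carries the change (ethyl in place of hydrogen on an amide-type nitrogen). Among the compounds with values here, the only measured step that bears on it is the growth of the alkyl on the urea nitrogen, a 2.4-fold higher number from compound 2 to compound 3 (0.38 log units; beyond the scatter), which raised the number modestly. Adding a second ethyl on the same nitrogen is therefore expected to raise the number again by a modest amount, possibly to the limit. The step from compound 3 to compound 4 is expected as a 1.9-fold higher number from compound 3 to compound 4 (0.29 log units; within the scatter), and compound 4 is estimated at 6000 nM, within 2500 nM to 15000 nM.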

Compound 4, half-maximal inhibitory concentration: 8700 nM
Compound 4: middle estimate off by 1.5-fold (0.16 log units), on the low side; the measured number falls inside the stated range.
By their numbers in this assay, from the lowest: compound 2; then compound 3; then compound 4. At a limit, above all of these: compound 1.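

In this assay, within the data shown here, replacing the remaining hydrogen on the amide-type nitrogen with ethyl gives a further rise, a 2.8-fold higher number from compound 3 to compound 4 (0.45 log units; beyond the scatter); the earlier compounds showed only a change of chain on a nitrogen that kept its hydrogen. Taken from methylamino to diethylamino on the carbonyl carbon, the change amounts to a 6.7-fold higher number from compound 2 to compound 4 (0.83 log units; beyond the scatter), and among the three urea compounds the number rises in the order compound 2, compound 3, compound 4, with none of the three going against that order. Set against the trifluoromethyl compound, the change reads an at least 1.1-fold lower number from compound 1 to compound 4 (0.06 log units; that floor lies within the scatter). Compound 1 alone gives a limit rather than a number: the limit of > 10000 nM in this assay, at which 1 of the 4 values shown sits.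

Still open, going by these compounds, is whether a plain amino group on the carbonyl carbon would give a lower number than compound 2, and whether a longer chain such as propyl would continue the rise. Also open, on these data alone, is how a ring such as morpholine on the same carbonyl carbon would compare with diethylamino, and the values shown give no reason for the rise.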